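This account rests on a few compounds, and the source may have more. Where it says the series, first, only, none or still open, it means among the compounds named here.

Measured so far:
compound 1 `COc1ccccc1N1C(=O)CSC1c1cc(F)cc(C(=O)O)c1`, 0% in a functional assay on HOS-TE85 cells (Homo sapiens) for inhibition, read by CCK-8 assay, with a stated time of 72 h, tested at 1 uM; a higher number here means more inhibition at the concentration tested (going by the name of the read-out), a lower number less inhibition
compound 2 `COc1cccc(OC)c1N1C(=O)CSC1c1cccc(C(=O)NCCCCc2ccccc2)c1`, 95%
compound 3 `CCOc1ccccc1N1C(=O)C(C)SC1c1cccc(C(=O)NCCCCc2ccccc2)c1`, 94%

Compound 2 stands at the top of these three numbers, yet compound 3 lies so close that the two cannot be told apart within the usual scatter, while compound 1 sits far below, beyond the scatter. Compound 4 `CCN1C(=O)CSC1c1cccc(C(=O)NCCCCc2ccccc2)c1` has not been measured. It differs from compound 2 in one place: ethyl in place of 2,6-dimethoxyphenyl on an amide-type nitrogen in a ring. Among the compounds with values here, no measured pair shows what this kind of change does, so the direction of the step is uncertain; a downward step beyond the scatter is expected, because compound 1 gives 0% once the shared pattern is broken, though compound 4 keeps the amide tail that compounds 2 and 3 share. Compound 4 is estimated at 60%, between 20% and 95%, a step of a number 35 percentage points lower from compound 2 to compound 4 (beyond the scatter) expected.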

Compound 4, a percentage reported as inhibition, at one concentration (the size of the read-out at that concentration, not a potency): 0%
Compound 4: middle estimate off by 60 percentage points, on the high side; measured number outside the range, below it.
By their numbers in this assay, from the lowest: compounds 1 and 4 (each within the scatter of the next); then compounds 3 and 2 (each within the scatter of the next).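

Putting ethyl in place of 2,6-dimethoxyphenyl on the amide-type nitrogen in the ring gives a number 95 percentage points lower from compound 2 to compound 4 (beyond the scatter) in this assay. This position therefore matters greatly, and at this concentration the amide tail that compound 4 keeps is not enough on its own. Nothing measured on these compounds gives a reason for the loss. As far as these compounds go, it remains open whether an unsubstituted phenyl on this nitrogen would retain the inhibition, which would show whether the two methoxy groups are needed. A longer chain such as hexyl would show whether a ring is needed here at all.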